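Replacing Difluoromethyl with 2-(Dimethylamino)ethyl: Will Half-Life Hold?

A few compounds are considered here, and "the series" means these few. Any claim that something is new, unique, unknown or untested is made for them only; others in the source may bear on it.

Of the compounds shown here, three that share one core have been measured in an ADME assay (liver, Mus musculus) for metabolic stability, using microsomes; a higher number here means that the compound lasts longer, a lower number that the compound disappears faster. Compound 1 (`C=CC(=O)Nc1cccc(CNc2nc(Nc3cc(F)c(N4CCN(C(C)=O)CC4)c(F)c3)ncc2Cl)c1`) gives 0.0567 h, compound 2 (`C=CC(=O)Nc1cccc(CNc2nc(Nc3cnoc3)ncc2Cl)c1`) gives 0.0583 h, and compound 3 (`C=CC(=O)Nc1cccc(CNc2nc(Nc3cnn(C(F)F)c3)ncc2Cl)c1`) gives 0.173 h, the highest number of the three.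

Compound 4 (`C=CC(=O)Nc1cccc(CNc2nc(Nc3cnn(CCN(C)C)c3)ncc2Cl)c1`) keeps all of compound 3 except one group, with 2-(dimethylamino)ethyl in place of difluoromethyl on an aromatic nitrogen. Among the measured compounds shown here, no measured pair makes this exact change, so the evidence is thin. For the measured compounds named here, the only measured step that bears on it is a 3.0-fold higher number from compound 2 to compound 3 (0.47 log units; beyond the scatter), where 1-(difluoromethyl)-1H-pyrazol-4-yl replaced 1,2-oxazol-4-yl. Going by the values given here, that step is modest, and it shows only that a change in this part of the structure can move the half-life. Among the compounds with values here, compound 3 is the only measured compound carrying difluoromethyl. Once that group leaves, the number may drift back toward compound 2 at 0.0583 h, although the new group is untested and could behave differently. The expected change is a 2.2-fold lower number from compound 3 to compound 4 (0.33 log units; beyond the scatter), a modest fall in this assay. For compound 4 the estimated half-life is 0.08 h, with an expected range from 0.04 h to 0.18 h.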

Compound 4, half-life: 0.03 h
Estimate against measurement, compound 4: 2.7-fold (0.43 log units) above; measured number below the stated range.
By their numbers in this assay, from the lowest: compounds 4, 1 and 2 (each within the scatter of the next); then compound 3.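

In this assay, a 5.8-fold lower number from compound 3 to compound 4 (0.76 log units; beyond the scatter) shows that the group on this aromatic nitrogen matters a great deal: the longer half-life of compound 3 does not survive when difluoromethyl gives way to 2-(dimethylamino)ethyl. The second comparison, a 1.9-fold lower number from compound 2 to compound 4 (0.29 log units; within the scatter), places 1-(2-(dimethylamino)ethyl)-1H-pyrazol-4-yl level with the 1,2-oxazol-4-yl group, so the five-membered ring with 2 nitrogen does not by itself bring the longer half-life seen for compound 3. Nothing available explains why the half-life moves with this change.

The compounds shown leave open whether the longer half-life of compound 3 goes with the fluorine atoms of difluoromethyl specifically, something a plain methyl or a trifluoromethyl on the same nitrogen could help to settle. They also leave open whether the result for compound 4 follows from the amine at the end of the chain or from the chain itself, which a 2-methoxyethyl group, an ethyl chain ending in an ether instead of an amine, could separate.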